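Compound 4: methyl in place of methoxy

The source may hold more compounds than are shown below. What is called first, only, known or untested is meant among the compounds shown, and "the series" means these compounds.

Compound 1 `Cc1ccc(-c2cc3ccccc3c(O)n2)cc1`: 7080 nM
Compound 2 `Cc1ccc2c(S)nc(-c3ccccc3)cc2c1`: 9120 nM; 75900 nM (2 entries)
Compound 3 `COc1ccc(-c2cc3cc(C)ccc3c(N3CCN(C)CC3)n2)cc1`: 7410 nM

In a functional assay on XF498 cells (Homo sapiens) for cytotoxicity (on this read-out lower numbers stand for stronger inhibition and higher numbers for weaker inhibition), compound 1 and compound 3 lie within the scatter of each other, with compound 3 at 7410 nM. Compound 2 has no single number, and its repeats spread widely: the several entries of compound 2 in this assay, 9120 nM; 75900 nM (2 entries).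

Compound 4 `Cc1ccc(-c2cc3cc(C)ccc3c(N3CCN(C)CC3)n2)cc1` differs from compound 3 in one place: methyl in place of methoxy on an aromatic carbon. It has methyl in place of methoxy on an aromatic carbon, turning 4-methoxyphenyl into 4-methylphenyl.

Going by the values given here, no measured pair tests this change, so no shift beyond the scatter is expected in this assay, in either direction. The estimated step is a 1.1-fold lower number from compound 3 to compound 4 (0.02 log units; within the scatter). Compound 4 is expected at 7000 nM, with an estimated range of 2800 nM to 18000 nM.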

Compound 4, half-maximal inhibitory concentration: 4470 nM
Compound 4: middle estimate off by 1.6-fold (0.19 log units), on the high side, and the stated range covers the measured number.
By their numbers in this assay, from the lowest: compounds 4, 1 and 3 (each within the scatter of the next).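

In this assay, the change from 4-methoxyphenyl to 4-methylphenyl gives a 1.7-fold lower number from compound 3 to compound 4 (0.22 log units; within the scatter), the first direct test of this position among the compounds shown. On an aromatic carbon para to a large group, this read-out therefore does not separate methoxy from methyl on this core. Repeats in this assay can also spread widely, which calls for caution with a step this small: the several entries of compound 2 in this assay, 9120 nM; 75900 nM (2 entries)

On these data alone, whether an amine, a carboxylic acid or a longer chain at this position would move the number beyond the scatter remains open. So does whether this change behaves the same way on another core.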